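The source may report more compounds than this note shows. Statements on the series, on what has been measured and on what is new or still open speak of the compounds shown alone.

Measured compounds in a functional assay on HeLa cells (Homo sapiens) for cytotoxicity, read by MTT assay, with a stated time of 72 h, tested at 1 uM; on this read-out lower numbers stand for less inhibition of growth and higher numbers for more inhibition of growth at the one concentration tested:
compound 1 `Cc1cccc(/C(N)=N/NC(=S)N2CCCCC2)n1`, 27%
compound 2 `Cc1cccc(/C(N)=N/NC(=S)N2CCCC2)n1`, 8.7%
compound 3 `Cc1ccnc(/C(N)=N/NC(=S)N2CCCCC2)c1`, 15.3%

Compound 1 and compound 3 have the same atoms joined differently; the difference between the two cores is not broken down here. Compound 3 stands nearer to compound 2 than to compound 1, within the scatter of compound 2 and beyond it from compound 1.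

For the measured compounds named here, the one counted change in the set is pyrrolidin-1-yl in place of piperidin-1-yl on a thiocarbonyl carbon. It gave a number 18.3 percentage points lower from compound 1 to compound 2 (beyond the scatter).

Compound 4 `Cc1ccnc(/C(N)=N/NC(=S)N2CCCC2)c1` carries the same change on the core of compound 3: pyrrolidin-1-yl in place of piperidin-1-yl on a thiocarbonyl carbon. The two place descriptions are identical word for word, so this is the same change on a different core. Going by the values given here, only one earlier instance exists, so its transfer is uncertain. Among the compounds with values here, because compound 3 starts from 15.3%, a step as large as the one in compound 1 cannot be expected in full; a smaller downward step is estimated, a number 11.3 percentage points lower from compound 3 to compound 4 (beyond the scatter). Compound 4 is thus expected at about 4% in this assay, with a range from -8% to 14%.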

Compound 4, percent growth inhibition at one concentration: 25.9%
Estimate against measurement, compound 4: 21.9 percentage points below; the whole stated range lies below it.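

In this assay, pyrrolidin-1-yl in place of piperidin-1-yl on a thiocarbonyl carbon gave a number 10.6 percentage points higher from compound 3 to compound 4 (beyond the scatter), so the direction of this change did not carry over from one core to the other: the same change on two cores in this assay, a number 18.3 percentage points lower (beyond the scatter) from compound 1 to compound 2 and a number 10.6 percentage points higher (beyond the scatter) from compound 3 to compound 4, 28.9 percentage points apart, beyond the scatter of two such steps

For these two pairs, the step measured on one core gives no usable guide to the step on the other, and the same swap cannot be treated as a fixed increment in this series. The pairs do not show which difference between the cores goes with the opposite steps, nor whether the pattern would persist at other concentrations, as each direction rests on a single pair read at one concentration.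

Still open, as far as these compounds go, is whether other cores follow the step seen on the core of compound 1 or the one seen on the core of compound 3. Also open, from the compounds shown here alone, is how morpholin-4-yl or a dimethylamino group on the same thiocarbonyl carbon would read on each of the two cores.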